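This account rests on a few compounds, and the source may have more. Where it says the series, first, only, none or still open, it means among the compounds named here.

Measured compounds:
- compound 1 `Cc1ccc(CSc2nc3ccccc3n2CC(=O)O)cc1`: 220 nM
- compound 2 `O=C(O)Cn1c(SCc2ccc(Br)cc2)nc2ccccc21`: 220 nM

In an assay on HEK293 cells for displacement of a labelled ligand from prostaglandin D2 receptor 2 (Homo sapiens) (a lower number here means a stronger inhibitor, a higher number a weaker inhibitor), compound 1 gives 220 nM and compound 2 gives 220 nM. Among the measured compounds shown here, the only step between them, no change at the digits printed from compound 1 to compound 2 (within the scatter), is a change on an aromatic carbon of a six-membered aromatic ring of carbon only, para to a large group. Compound 2 therefore stands level with compound 1 at the digits shown, within the scatter.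

Compound 3 `COC(=O)c1ccc(CSc2nc3ccccc3n2CC(=O)O)cc1` is not yet measured in this assay. It differs from compound 2 by methoxycarbonyl in place of bromo on an aromatic carbon, at the same place on the ring where bromo earlier replaced methyl. For the measured compounds named here, the one step that bears on this position, no change at the digits printed from compound 1 to compound 2 (within the scatter), was flat, so the ring position so far tolerates exchange of a small group without a shift beyond the scatter. Going by the values given here, no step tests a group of the size of methoxycarbonyl here, so the expectation rests on that single flat step alone.

Compound 3 is expected to give about 300 nM in this assay, with a range of 100 nM to 900 nM. The expected step of a 1.4-fold higher number from compound 2 to compound 3 (0.13 log units; within the scatter) is a slight weakening or none beyond the scatter.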

Compound 3, half-maximal inhibitory concentration: 10600 nM
Compound 3: the middle estimate sits 35-fold (1.55 log units) below what was measured; the measured number lies above the stated range.
By their numbers in this assay, from the lowest: compounds 1 and 2 (each within the scatter of the next); then compound 3.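

In this assay, this aromatic carbon, para to a large group, does not accept every exchange: methoxycarbonyl in place of bromo brings a 48-fold higher number from compound 2 to compound 3 (1.68 log units; beyond the scatter), and methoxycarbonyl in place of methyl brings a 48-fold higher number from compound 1 to compound 3 (1.68 log units; beyond the scatter). The flat step, no change at the digits printed from compound 1 to compound 2 (within the scatter), therefore holds only for methyl and bromo and does not extend to methoxycarbonyl, which has 4 heavy atoms and 2 hydrogen-bond acceptors where bromo has 1 heavy atom and 0 hydrogen-bond acceptors. No available evidence ties the loss to any one of these differences.

On these data alone, it remains open whether the loss goes with the number of heavy atoms, with the hydrogen-bond acceptors, or with some other feature of the ester, and a nitrile, a carboxylic acid or a methoxy group on this same aromatic carbon would give further points for comparison. Also open, as far as these compounds go, is whether methoxycarbonyl gives a similar result on the other carbons of this ring, or whether the result is confined to this one position.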